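The source may hold more compounds than are shown below. What is called first, only, known or untested is meant among the compounds shown, and "the series" means these compounds.

Measured compounds in an assay for inhibition of Fatty-acid amide hydrolase 1 (Rattus norvegicus), using a Dixon plot; on this read-out lower numbers stand for stronger inhibition and higher numbers for weaker inhibition:
compound 1 `O=C(CCCCCCc1ccccc1)c1ncc(-c2ccc(CO)cn2)o1`, 3.2 nM;
compound 2 `O=C(CCCCCCc1ccccc1)c1ncc(-c2ccc(CCl)cn2)o1`, 22.4 nM;
compound 3 `CSCc1ccc(-c2cnc(C(=O)CCCCCCc3ccccc3)o2)nc1`, 11.1 nM.

Compound 3 stands second highest of the three; its nearest neighbour is compound 2, a 2.0-fold lower number from compound 2 to compound 3 (0.30 log units; within the scatter), within the scatter, and its furthest is compound 1, a 3.5-fold higher number from compound 1 to compound 3 (0.54 log units; beyond the scatter). Compound 4 `O=C(O)CCCCc1cnc(C(=O)CCCCCCc2ccccc2)o1` differs from compound 3 by a group of 7 heavy atoms (5 carbon, 2 oxygen; no ring) in place of a group of 9 heavy atoms (7 carbon, 1 nitrogen, 1 sulfur; one six-membered aromatic ring with 1 hetero atom), on an aromatic carbon. Among the compounds with values here, none of the measured steps bears directly on this change: a 7.0-fold higher number from compound 1 to compound 2 (0.85 log units; beyond the scatter) and a 3.5-fold higher number from compound 1 to compound 3 (0.54 log units; beyond the scatter) concern only the substituent on the six-membered ring, and that ring itself now leaves. The step is therefore uncalibrated here; a move toward weaker inhibition beyond the scatter is expected, a 5.4-fold higher number from compound 3 to compound 4 (0.73 log units; beyond the scatter). For compound 4 in this assay the estimate is 60 nM, with a range from 12 nM to 300 nM.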

Compound 4, inhibition constant: 23.8 nM
For compound 4 the middle estimate is 2.5-fold (0.40 log units) above the measured one; the measured number falls inside the stated range.
By their numbers in this assay, from the lowest: compound 1; then compounds 3, 2 and 4 (each within the scatter of the next, the first and the last beyond it).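

In this assay, the 4-carboxybutyl chain, which has no ring, can replace the whole six-membered aromatic ring on this aromatic carbon at only a modest cost (a 2.1-fold higher number from compound 3 to compound 4 (0.33 log units; beyond the scatter)), and with no difference beyond the scatter against the chloro compound (a 1.1-fold higher number from compound 2 to compound 4 (0.03 log units; within the scatter)). Only the 5-(hydroxymethyl)pyridin-2-yl group holds a clear lead over it (a 7.4-fold higher number from compound 1 to compound 4 (0.87 log units; beyond the scatter)). No evidence is available to explain these steps.

Going by these compounds, what a methyl ester, an amine or a longer chain would give at this carbon stays open. Also open, on these data alone, is whether the carboxylic acid end or the chain length carries the result.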